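A Methylsulfonyl Group Replaces an Arylcarbonyl on the Ring Nitrogen

The compounds below may be only part of what the source reports. "The series", "measured", "known", "first", "only" and "open" are said of these compounds alone.

Compound 2 `CN(C)c1ccc(C2CC(c3ccc(-n4ccnc4)cc3)=NN2C(=O)c2ccc(C(F)(F)F)cc2)cc1` stands higher of the two measured compounds. In a functional assay on HCC1806 cells (Homo sapiens) for inhibition, read by sulforhodamine B assay, tested at 10 uM (a lower number here means less inhibition, a higher number more inhibition at the concentration tested (going by the name of the read-out)), compound 2 gives 28%, while compound 1 `COC(=O)CC(=O)N1N=C(c2ccc(-n3ccnc3)cc2)CC1c1ccc(N(C)C)cc1` gives 2.1%. Among the compounds with values here, the only measured step, a number 25.9 percentage points higher from compound 1 to compound 2 (beyond the scatter), shows that exchanging a small, ring-free group on the carbonyl carbon for a six-membered aromatic ring raised the read-out modestly, beyond the scatter.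

Compound 3 `CN(C)c1ccc(C2CC(c3ccc(-n4ccnc4)cc3)=NN2S(C)(=O)=O)cc1` has not yet been measured. It differs from compound 2 in one place: methylsulfonyl in place of (4-(trifluoromethyl)phenyl)carbonyl on an amine nitrogen in a ring. This change sits on the same amine nitrogen in the ring and runs in the opposite sense to the measured step: a group carrying a six-membered aromatic ring leaves and a four-atom group with no ring enters. On that basis the expectation is a fall of about the size seen in the measured step, so for compound 3 a step of a number 20 percentage points lower from compound 2 to compound 3 (beyond the scatter) is estimated. In this assay compound 3 is therefore expected to give 8%, with a likely range from 0% to 25%.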

Compound 3, a percentage reported as inhibition, at one concentration (the size of the read-out at that concentration, not a potency): 11.3%
The estimate for compound 3 lay 3.3 percentage points below the measured number, and the stated range covers the measured number.
By their numbers in this assay, from the lowest: compounds 1 and 3 (each within the scatter of the next); then compound 2.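

In this assay the ring nitrogen has now been changed in a second way: a number 16.7 percentage points lower from compound 2 to compound 3 (beyond the scatter), and here the carbonyl that stayed in place in the earlier step is itself replaced, so the read-out responds to a change of the linking group as well as of what it carries. The comparison of the two ring-free groups, a number 9.2 percentage points higher from compound 1 to compound 3 (within the scatter), separates methylsulfonyl from ((methoxycarbonyl)methyl)carbonyl by no more than the scatter, so among these three compounds, with none going against it, only compound 2, the one carrying a six-membered aromatic ring on this nitrogen, stands apart from the others. Nothing available explains why these groups differ as they do.

The compounds shown cannot say whether the aromatic ring or its trifluoromethyl group accounts for the higher number, a question that a plain phenylcarbonyl group would address. They also leave open whether a phenylsulfonyl group on the same nitrogen would restore the read-out, and so whether the sulfonyl link itself matters at all.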